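Aryl sulfonate esters: variation at the ester oxygen

A few compounds are considered here, and "the series" means these few. Any claim that something is new, unique, unknown or untested is made for them only; others in the source may bear on it.

Compound 1 `CN1CCN(c2ccc(S(=O)(=O)Oc3cc(Cl)c(Cl)cc3Cl)cc2)C1=O` gives 600 nM in a functional assay on HT-29 cells (Homo sapiens) for antiproliferative activity, read by sulforhodamine B assay, with a stated time of 48 h; on this read-out lower numbers stand for stronger inhibition and higher numbers for weaker inhibition. Compound 2 `CCN1CCN(c2ccc(S(=O)(=O)Oc3cc(OC)c(OC)c(OC)c3)cc2)C1=O` gives 640 nM in this assay. Among the measured compounds shown here, compound 3 `CCCN1CCN(c2ccc(S(=O)(=O)Oc3cc(Cl)c(Cl)cc3Cl)cc2)C1=O` gives 19000 nM in this assay, the highest of the three numbers; the only single-place step onto it is a 32-fold higher number from compound 1 to compound 3 (1.50 log units; beyond the scatter), and compound 2 differs from compound 3 in two places at once. Compound 4 `CCCN1CCN(c2ccc(S(=O)(=O)Oc3ccc(Cl)cc3)cc2)C1=O` differs from compound 3 by 4-chlorophenyl in place of 2,4,5-trichlorophenyl on an oxygen, on an oxygen whose other neighbour is sulfonyl sulfur. For the measured compounds named here, no measured step alters this group alone, so nothing measured bears on it directly, and no change beyond the scatter is expected in this assay: no change at the digits printed from compound 3 to compound 4 (within the scatter). Compound 4 is therefore estimated at 19000 nM, within 5000 nM to 70000 nM.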

Compound 4, half-maximal inhibitory concentration: 15000 nM
Beside the measured number, compound 4's estimate is 1.3-fold (0.10 log units) above it; the range from low to high includes it.
By their numbers in this assay, from the lowest: compounds 1 and 2 (each within the scatter of the next); then compounds 4 and 3 (each within the scatter of the next).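

Among the compounds shown here, on the core of compound 3, the step of a 1.3-fold lower number from compound 3 to compound 4 (0.10 log units; within the scatter) in this assay is the first measured change to the aryl group on the oxygen whose other neighbour is sulfonyl sulfur. Here, 4-chlorophenyl in place of 2,4,5-trichlorophenyl gives no difference beyond the scatter, which holds for this one pair only. Nothing measured explains this result.

Going by these compounds, it remains open whether the same exchange would read alike on the core of compound 1. An aryl group carrying an amine or a carboxylic acid at this oxygen also remains untested in the compounds shown.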